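Chloro for hydrogen on the imine arm of the series

The compounds below may be only part of what the source reports. "The series", "measured", "known", "first", "only" and "open" are said of these compounds alone.

Three compounds of the shared core have numbers in an assay for inhibition of kynurenine 3-monooxygenase (Rattus norvegicus), tested at 10 uM (on this read-out higher numbers stand for more inhibition at the one concentration tested (going by the name of the read-out) and lower numbers for less inhibition), so far. Compound 1 `COC(=O)C(=O)/C=C(\O)c1ccccc1Cl` gives 31% in this assay, and compound 2 `COC(=O)C(=O)/C=C(\O)c1ccc(F)cc1` gives 22%; these two values lie within the scatter of each other, so no order between them is read. Compound 3 `COC(=O)C(=N)/C=C(\O)c1ccccc1` gives 3% and stands lowest of the three, with compound 2 nearest, a number higher by more than the scatter, and compound 1 furthest, also beyond the scatter.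

The next compound, compound 4 `COC(=O)C(=N)/C=C(\O)c1ccccc1Cl`, differs from compound 3 in one place: chloro in place of hydrogen on an aromatic carbon. Among the measured compounds shown here, no step between two measured compounds isolates this change, since compound 1 and compound 3 differ in more than this one position. In this assay a step of modest size upward from compound 3 is expected, though a step within the scatter cannot be ruled out. Compound 4 is estimated at 12%, with a range from 0% to 30%, which corresponds to an expected step of a number 9 percentage points higher from compound 3 to compound 4 (within the scatter).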

Compound 4, a percentage reported as inhibition, at one concentration (the size of the read-out at that concentration, not a potency): 31%
The estimate for compound 4 lay 19 percentage points below the measured number, outside the stated range (above it).
By their numbers in this assay, from the lowest: compound 3; then compounds 2, 1 and 4 (each within the scatter of the next).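

Among the compounds shown here, on this aromatic carbon, ortho to a group of 9 heavy atoms, chloro in place of hydrogen gives the first single-place step: in this assay, a number 28 percentage points higher from compound 3 to compound 4 (beyond the scatter). This shows that, on the imine arm, the position responds to this one-atom change. Compound 1 gives 31% and compound 4 gives 31%, the same printed number for two compounds that differ only in carbonyl versus imine, so with chloro in place that exchange shows no separation here. No measured evidence bears on the origin of the step.

On these data alone, whether the imine matters when hydrogen occupies this position remains open. Also open, as far as these compounds go, is whether the step is specific to chloro or would also appear with an amine or a methoxy group at the same carbon.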